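A Methoxy Replaces Formylamino on a Fused Core

The source may hold more compounds than are shown below. What is called first, only, known or untested is meant among the compounds shown, and "the series" means these compounds.

Compound 1 `Cc1nc2c(CCc3ccccc3)cccn2c1N` and compound 2 `Cc1nc2c(OCc3ccccc3)cccn2c1NC=O` share a core, and both have been tested in a functional assay on the whole organism with Rattus norvegicus as the target; a lower number here means that less compound is needed, a higher number that more compound is needed for the effect. Compound 1 gives 9 mg/kg, and compound 2 gives 10 mg/kg; the two values sit within the usual scatter of each other, so neither stands apart. Compound 3 `COc1c(C)nc2c(OCc3ccccc3)cccn12` differs from compound 2 in one place: methoxy in place of formylamino on an aromatic carbon. Among the compounds with values here, no pair of measured compounds shows such a change, so its effect is unknown. In this assay compound 3 is expected to differ little, a step of no change at the digits printed from compound 2 to compound 3 (within the scatter) not beyond the scatter. The estimate for compound 3 is 10 mg/kg, in the range from 4 mg/kg to 25 mg/kg.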

Compound 3, dose for half-maximal effect: 3.6 mg/kg
Compound 3: the middle estimate sits 2.8-fold (0.44 log units) above what was measured; the whole stated range lies above it.
By their numbers in this assay, from the lowest: compound 3; then compounds 1 and 2 (each within the scatter of the next).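

In this assay, the aromatic carbon of the five-membered ring is shown to respond to its substituent: methoxy in place of formylamino gives a 2.8-fold lower number from compound 2 to compound 3 (0.44 log units; beyond the scatter). The hydrogen-bond donor that leaves with formylamino is therefore not required for the effect in this pair, and less compound is needed without it. Nothing available accounts for the size of this step.

This single step cannot separate the departure of formylamino from the arrival of methoxy. On these data alone, whether ethoxy or a hydroxy group on this carbon would lower the number further remains open.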